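Compound 1 to compound 3: a side-chain exchange

The compounds below may be only part of what the source reports. "The series", "measured", "known", "first", "only" and "open" are said of these compounds alone.

Measured in an ADME assay on microsomes from liver (Rattus norvegicus) for metabolic stability, read by LC-MS, with a stated time of 10 min, tested at 0.5 uM; a lower number here means that less of the compound is left, a higher number that more of the compound is left:
Compound 1 `CC(C)N1CCN(CCCN(C[C@H]2Cc3ccccc3CN2)[C@H]2CCCc3cccnc32)CC1`: 4%
Compound 2 `c1cnc2c(c1)CN[C@@H](CN(CCCN1CCNCC1)[C@H]1CCCc3cccnc31)C2`: 79%

Of these two compounds, compound 1 stands lowest, and compound 2 lies above it by a margin beyond the scatter. The next compound to be tested is compound 3 `c1ccc2c(c1)CN[C@@H](CN(CC[C@H]1CCCNC1)[C@H]1CCCc3cccnc31)C2`. Its difference from compound 1 is piperidin-3-yl in place of (4-isopropylpiperazin-1-yl)methyl on a saturated chain carbon, two bonds along the chain from an amine nitrogen, which means piperidin-3-yl in place of (4-isopropylpiperazin-1-yl)methyl on a saturated chain carbon, two bonds along the chain from an amine nitrogen. Going by the values given here, no measured pair isolates this change. Among the compounds with values here, the only guide is compound 2, at 79%, which differs from compound 1 in more than one place, so any forecast remains loose. An upward move beyond the scatter is expected, with an estimated a number 36 percentage points higher from compound 1 to compound 3 (beyond the scatter) in this assay. For compound 3 the expected value is 40%, with an estimated range from 15% to 72% for the coming measurement.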

Compound 3, percent of the compound remaining: 55%
Beside the measured number, compound 3's estimate is 15 percentage points below it; low and high end bracket the measured number.
By their numbers in this assay, from the lowest: compound 1; then compound 3; then compound 2.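

In this assay, piperidin-3-yl in place of (4-isopropylpiperazin-1-yl)methyl on a saturated chain carbon, two bonds along the chain from an amine nitrogen, gives a number 51 percentage points higher from compound 1 to compound 3 (beyond the scatter) and is the only single-place step shown. It shows that this position alone can carry a large change in the percent of compound remaining, with the rest of compound 1 left as it is. Nothing at hand gives a cause for this step. 

The exchange alters several things at once, including the ring, the isopropyl group, the second ring nitrogen and the defined stereocentre, so the compounds shown do not say which of them matters. As far as these compounds go, it also stays open whether a piperidin-4-yl group, or an isopropyl group on the piperidine nitrogen, would keep the number near that of compound 3 or return it towards that of compound 1.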